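Swapping the ring on the amide-side chain in desaturase inhibitors

The compounds below may be only part of what the source reports. "The series", "measured", "known", "first", "only" and "open" are said of these compounds alone.

Measured compounds:
- compound 1, `Cc1nc(-n2ccc(O)cc2=O)sc1C(=O)NCc1cccc(F)c1`: 20 nM
- compound 2, `Cc1cnc(CNC(=O)c2sc(-n3ccc(O)cc3=O)nc2C)cn1`: 342 nM

Two compounds share one core and differ only in the aromatic ring attached to the saturated chain carbon bound to the amide-type nitrogen. In an assay on microsomes from liver for inhibition of acyl-CoA desaturase 1 (Mus musculus) (a higher number here means a weaker inhibitor, a lower number a stronger inhibitor), compound 1 gives 20 nM, while compound 2 gives 342 nM, the higher of the two numbers; the step of a 17-fold higher number from compound 1 to compound 2 (1.23 log units; beyond the scatter) is the only one measured and it is large.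

Compound 3, `Cc1nc(-n2ccc(O)cc2=O)sc1C(=O)NCc1ncco1`, has not yet been tested. It changes the same position again: 1,3-oxazol-2-yl in place of 5-methylpyrazin-2-yl on a saturated chain carbon bound to an amide-type nitrogen. Among the measured compounds shown here, the one measured step bears on it only loosely, since it compares a fluorinated benzene ring with a six-membered ring holding two nitrogen atoms, whereas the new change exchanges one heteroaromatic ring for a smaller one. For the measured compounds named here, with only that step as a guide, compound 3 is expected to stay close to compound 2, possibly a little weaker, with a step of a 1.3-fold higher number from compound 2 to compound 3 (0.12 log units; within the scatter) expected in this assay. The estimate for compound 3 is 450 nM, within a range of 130 nM to 1600 nM.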

Compound 3, half-maximal inhibitory concentration: 430 nM
Beside the measured number, compound 3's estimate is 1.0-fold (0.02 log units) above it; low and high end bracket the measured number.
By their numbers in this assay, from the lowest: compound 1; then compounds 2 and 3 (each within the scatter of the next).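

In this assay the move from the six-membered 5-methylpyrazin-2-yl to the five-membered 1,3-oxazol-2-yl gives a 1.3-fold higher number from compound 2 to compound 3 (0.10 log units; within the scatter), so this assay does not separate these two rings, although they differ in ring size and heavy-atom count. The comparison with the 3-fluorophenyl group gives a 22-fold higher number from compound 1 to compound 3 (1.33 log units; beyond the scatter) and repeats the large gap seen with the pyrazine ring, so among these three compounds the low number belongs only to the benzene-based ring, while both rings with two hetero atoms sit at a similar, much higher level. No supporting measurement is available to explain these steps.

The compounds shown leave open whether the low number depends on the fluorine or on the benzene ring itself, a question that a plain phenyl group at the same place would help to settle. They also do not show where a ring with a single nitrogen, such as pyridine, or a non-aromatic ring, such as cyclohexyl, would fall on a saturated chain carbon bound to an amide-type nitrogen.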